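A Hydroxy-Methoxy Swap on the Hydrazone Arm

The source may hold more compounds than are shown below. What is called first, only, known or untested is meant among the compounds shown, and "the series" means these compounds.

Compound 2 `COc1ccc(/C=N/NC(=O)Nc2ccc(Oc3ccnc(-c4nncn4CCN(C)C)c3)c(F)c2)c(OC)c1OC` stands without a single number in an ADME assay on WI-38 cells (Homo sapiens) for cytotoxicity, read by MTT assay, with a stated time of 72 h; a lower number here means a stronger inhibitor, a higher number a weaker inhibitor: its result there is "not determined" (no result reported), and compound 3 `CN(C)CCn1cnnc1-c1cc(Oc2ccc(NC(=O)N/N=C/c3ccc(O)c(F)c3)cc2F)ccn1` likewise has no reported result, its entry being "not determined" (no result reported). Within the data shown here, the only number comes from compound 1 `COc1ccc(/C=N/NC(=O)Nc2ccc(Oc3ccnc(-c4nncn4CCN(C)C)c3)c(F)c2)c(OC)c1`, which in this assay gives 6630 nM. Compound 4 `COc1cc(/C=N/NC(=O)Nc2ccc(Oc3ccnc(-c4nncn4CCN(C)C)c3)c(F)c2)ccc1O` is the next compound to be measured. It differs from compound 2 by 4-hydroxy-3-methoxyphenyl in place of 2,3,4-trimethoxyphenyl on a carbon with a double bond to nitrogen. Among the measured compounds shown here, with no step between measured compounds available, the size of the move from compound 2 to compound 4 in this assay cannot be read from the data; the expectation is a step no larger than the usual scatter, in no firm direction. Compound 4 is therefore expected to give about 7000 nM in this assay, with a range from 2000 nM to 25000 nM.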

Compound 4, half-maximal inhibitory concentration: 5320 nM
Compound 4: the middle estimate sits 1.3-fold (0.12 log units) above what was measured; low and high end bracket the measured number.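

Replacing 2,4-dimethoxyphenyl with 4-hydroxy-3-methoxyphenyl on a carbon with a double bond to nitrogen gives a 1.2-fold lower number from compound 1 to compound 4 (0.10 log units; within the scatter) in this assay, so this first readable change at the position leaves the result within the scatter. The steps from compound 2 and compound 3 to compound 4 cannot be read. Nothing available explains the result.

Still open, as far as these compounds go, is whether a phenyl ring bearing an amine or a carboxylic acid at this position would move the number beyond the scatter. Also open, from the compounds shown here alone, is how compound 2 and compound 3 would read here.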